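Methyl on the piperidine ring of compound 3

The source may hold more compounds than are shown below. What is called first, only, known or untested is meant among the compounds shown, and "the series" means these compounds.

Compound 1, `CSc1c(C#N)c(N)c(C#N)c(-c2ccccc2)c1-c1ccccc1`: 7.4%
Compound 2, `CSc1c(C)c(-c2ccccc2)c(C#N)c(N)c1C#N`: 0.96%
Compound 3, `Cc1c(-c2ccccc2)c(C#N)c(N)c(C#N)c1N1CCCCC1`: 38.2%

In an assay on isolated protein for inhibition of glucose-6-phosphatase catalytic subunit 1 (Homo sapiens), tested at 100 uM (a lower number here means less inhibition, a higher number more inhibition at the concentration tested (going by the name of the read-out)), compound 3 stands highest of the three, with both other compounds lying beyond the scatter below it. Compound 4, `Cc1c(-c2ccccc2)c(C#N)c(N)c(C#N)c1N1CCC(C)CC1`, differs from compound 3 by methyl in place of hydrogen on a saturated ring carbon. Neither measured step concerns such a change: the step of a number 6.4 percentage points lower from compound 1 to compound 2 (within the scatter) swaps groups on an aromatic carbon and stays within the scatter, while the step of a number 37.2 percentage points higher from compound 2 to compound 3 (beyond the scatter) replaces the whole substituent at the position that carries the ring in compound 4. Among the measured compounds shown here, no measured pair shows what a methyl added to that saturated ring does, so no step beyond the scatter is expected, and compound 4 is estimated at 38%, between 20% and 56%, an expected step of a number 0.2 percentage points lower from compound 3 to compound 4 (within the scatter).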

Compound 4, a percentage reported as inhibition, at one concentration (the size of the read-out at that concentration, not a potency): 10.9%
Compound 4: the middle estimate sits 27.1 percentage points above what was measured; the measured number lies below the stated range.
By their numbers in this assay, from the lowest: compounds 2, 1 and 4 (each within the scatter of the next); then compound 3.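

In this assay the saturated ring carbon three ring bonds from the ring nitrogen proves sensitive: a single added methyl gives a number 27.3 percentage points lower from compound 3 to compound 4 (beyond the scatter) and undoes most of what piperidin-1-yl had gained. Replacing methylsulfanyl with 4-methylpiperidin-1-yl gives a number 9.9 percentage points higher from compound 2 to compound 4 (within the scatter) and so keeps no clear gain, unlike piperidin-1-yl. On these data alone, whether an ethyl or a hydroxyl group on that same carbon would act as methyl does remains open. Nothing available here says why this methyl has such an effect.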